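The source may hold more compounds than are shown below. What is called first, only, known or untested is meant among the compounds shown, and "the series" means these compounds.

Measured so far in an assay for positive allosteric modulation of metabotropic glutamate receptor 3 (Rattus norvegicus); a higher number here means that more compound is needed for the effect, a lower number that less compound is needed:
compound 1, `Cc1c(O[C@H](C)COc2ccc(F)c(C(=O)O)c2)ccc(C(=O)CC(C)(C)C)c1O`: 2410 nM
compound 2, `COc1ccc(C(=O)O)cc1OC[C@H](C)COc1ccc(C(=O)CC(C)(C)C)c(O)c1C`: 384 nM
compound 3, `Cc1c(OC[C@@H](C)COc2cc(C(=O)O)ccc2F)ccc(C(=O)CC(C)(C)C)c1O`: 3950 nM

Compound 3 gives the highest of the three numbers in this assay; compound 1 stands nearest to it, within the scatter, while compound 2 stands furthest, beyond the scatter. Going by the values given here, the only step measured between two compounds that differ in one place is a 10-fold higher number from compound 2 to compound 3 (1.01 log units; beyond the scatter).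

Compound 4, `Cc1c(OC[C@@H](C)COc2ccc3c(c2)C(=O)NC3)ccc(C(=O)CC(C)(C)C)c1O`, is not yet measured. It differs from compound 3 in a group of 10 heavy atoms (8 carbon, 1 nitrogen, 1 oxygen; one five-membered non-aromatic ring with 1 hetero atom, one six-membered aromatic ring of carbon only) in place of a group of 10 heavy atoms (7 carbon, 2 oxygen, 1 fluorine; one six-membered aromatic ring of carbon only), on an oxygen on a saturated carbon.

Among the compounds with values here, no measured step exchanges a whole ring-bearing group on that oxygen, so the bearing of the series on this change is indirect. Within the data shown here, the one measured step, a 10-fold higher number from compound 2 to compound 3 (1.01 log units; beyond the scatter), altered a single substituent on the six-membered aromatic ring that now leaves, yet moved the number widely; a replacement of the entire group may therefore move the number at least as much, and the direction cannot be read from the data. The entering group carries the same counted number of hydrogen-bond donors and acceptors as the leaving group, which gives no firm reason to expect a step beyond the scatter, but the uncertainty is wide. For compound 4 in this assay an expected value of 2000 nM is estimated, with a range from 300 nM to 12000 nM. This estimate corresponds to an expected step of a 2.0-fold lower number from compound 3 to compound 4 (0.30 log units; within the scatter).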

Compound 4, half-maximal effective concentration: "not active" (no number reported)
Compound 4 has no reported number here, and the estimate cannot be compared.
By their numbers in this assay, from the lowest: compound 2; then compounds 1 and 3 (each within the scatter of the next).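

In this assay, going by these compounds alone, compound 4 is reported as "not active" without a number, so no step from compound 3 to compound 4 can be read. No available evidence bears on this result. The compounds shown leave open which part of the exchange of the 5-carboxy-2-fluorophenyl group goes with that report.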